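Swapping the amide of compound 1 for a benzyl ester

A few compounds are considered here, and "the series" means these few. Any claim that something is new, unique, unknown or untested is made for them only; others in the source may bear on it.

Compound 1 `CCn1c(C(=O)NCC(OC)OC)ccc1C(CC)(CC)c1ccc(OCC(=O)C(C)(C)C)c(C)c1`: 130 nM
Compound 2 `CCn1c(C(=O)NCC(OC)OC)ccc1C(CC)(CC)c1ccc(OCC(O)C(C)(C)C)c(C)c1`: 150 nM
Compound 3 `CCn1c(C(=O)Oc2ccc(CCO)cc2)ccc1C(CC)(CC)c1ccc(OCC(O)C(C)(C)C)c(C)c1`: 5100 nM

In an assay on HL-60 cells for agonist activity at vitamin D3 receptor (Homo sapiens), read by microscopy, with a stated time of 96 h (on this read-out higher numbers stand for an effect only at larger amounts of compound and lower numbers for an effect already at smaller amounts), compound 1 gives 130 nM, the lowest of the three numbers, although its gap to compound 2 is within the scatter, with a 1.2-fold higher number from compound 1 to compound 2 (0.06 log units; within the scatter). Compound 3 lies far beyond the scatter, with a 34-fold higher number from compound 2 to compound 3 (1.53 log units; beyond the scatter).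

Compound 4 `CCn1c(C(=O)OCc2ccc(F)cc2)ccc1C(CC)(CC)c1ccc(OCC(=O)C(C)(C)C)c(C)c1` is not yet measured. It differs from compound 1 at the carbonyl carbon on the shared core: (4-fluorobenzyl)oxy in place of (2,2-dimethoxyethyl)amino on a carbonyl carbon. The amide therefore becomes an ester carrying an aromatic ring.

Going by the values given here, the one measured step bearing on this is the change from an amide to an ester with an aromatic ring, a 34-fold higher number from compound 2 to compound 3 (1.53 log units; beyond the scatter), which was large. Compound 4 carries a (4-fluorobenzyl)oxy group rather than the ester group of compound 3, so the size is uncertain, but the direction is expected to be the same. For compound 4 the expected step is a 19-fold higher number from compound 1 to compound 4 (1.28 log units; beyond the scatter) in this assay. Compound 4 is therefore estimated at 2500 nM, with a range from 600 nM to 10000 nM.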

Compound 4, half-maximal effective concentration: 9500 nM
The estimate for compound 4 lay 3.8-fold (0.58 log units) below the measured number, within the range that was stated.
By their numbers in this assay, from the lowest: compounds 1 and 2 (each within the scatter of the next); then compounds 3 and 4 (each within the scatter of the next).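

In this assay, placing (4-fluorobenzyl)oxy on the carbonyl carbon gives a 73-fold higher number from compound 1 to compound 4 (1.86 log units; beyond the scatter), so much more compound is needed for the same effect. The earlier large step away from the amide came with the alcohol side chain, and this one shows a large step at the same carbonyl carbon with the (tert-butyl)carbonyl side chain, so the finding no longer rests on one side chain. No measurement available here explains this change in the numbers.

The swap removes the amide hydrogen and brings in an aromatic ring at once, so the compounds shown leave open which of these changes matters. A benzylamino group on this carbonyl carbon would keep the ring and the amide hydrogen together, while a small methyl ester or a carboxylic acid would test this position without the ring.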